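Methyl for Methoxy on the Fused Ring of Compound 2

The source may report more compounds than this note shows. Statements on the series, on what has been measured and on what is new or still open speak of the compounds shown alone.

Going by the values given here, compound 2 `COc1ccc2nc(NC(=O)c3cn(-c4ccccc4)nc3-c3ccc(Cl)cc3)sc2c1` gives 29300 nM in a functional assay on PC-3 cells (Homo sapiens) for cytotoxicity, read by MTT assay, with a stated time of 72 h (on this read-out higher numbers stand for weaker inhibition and lower numbers for stronger inhibition), the higher of the two numbers measured so far. Compound 1 `O=C(Nc1nc2ccc(Cl)cc2s1)c1cn(-c2ccccc2)nc1-c1ccc(Cl)cc1` gives 3230 nM in this assay. Among the compounds with values here, the one measured step between them, a 9.1-fold higher number from compound 1 to compound 2 (0.96 log units; beyond the scatter), concerns a different exchange than the one now in question, but it is the only comparison at hand. Compound 3 `Cc1ccc2nc(NC(=O)c3cn(-c4ccccc4)nc3-c3ccc(Cl)cc3)sc2c1` differs from compound 2 by methyl in place of methoxy on an aromatic carbon. Within the data shown here, no measured step exchanges methoxy for methyl, so the expectation rests loosely on the two numbers above: the methoxy analogue, compound 2, carries the highest number, the chloro analogue, compound 1, a far lower one, and methyl is neither of these groups. The step expected from this change is a 2.9-fold lower number from compound 2 to compound 3 (0.47 log units; beyond the scatter), a downward move of uncertain size. Compound 3 is estimated at 10000 nM, within a range from 3000 nM to 40000 nM.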

Compound 3, half-maximal inhibitory concentration: 14500 nM
The estimate for compound 3 lay 1.5-fold (0.16 log units) below the measured number, and the stated range covers the measured number.
By their numbers in this assay, from the lowest: compound 1; then compound 3; then compound 2.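

In this assay, methyl in place of methoxy on this aromatic carbon gives a 2.0-fold lower number from compound 2 to compound 3 (0.31 log units; beyond the scatter), so the high number of compound 2 does not hold for every small group at this position. Methyl does not match chloro, however, as the step of a 4.5-fold higher number from compound 1 to compound 3 (0.65 log units; beyond the scatter) shows: among these three groups at this one position, compound 1 with chloro keeps the lowest number and compound 3 falls between the other two. Nothing available explains why the three groups fall in this order.

The compounds shown leave open how an amine, a hydroxyl group or a longer chain such as ethoxy would read at this position, and whether any group here could go lower than chloro. They also leave open whether the same order would hold with other groups on the rest of the shared core.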